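The compounds below may be only part of what the source reports. "The series", "measured", "known", "first", "only" and "open" are said of these compounds alone.

Working notes on the series in a functional assay on RPMI-8226 cells (Homo sapiens) for cytotoxicity, read by MTT assay, with a stated time of 48 h; on this read-out lower numbers stand for stronger inhibition and higher numbers for weaker inhibition. Here compound 1 `O=C(c1ccccc1)N(N=C1C(Cl)=C(Cl)C(Cl)=C1Cl)C(=O)c1ccccc1` gives 800 nM, the only true number so far. Compound 2 `C#CC(C)(C)OC(=O)NN=C1C(Cl)=C(Cl)C(Cl)=C1Cl` reads > 5000 nM, which is a limit of the assay. Compound 3 `CC(C)(C)NN=C1C(Cl)=C(Cl)C(Cl)=C1Cl` reads > 3000 nM, also a limit of the assay, so it has no exact place on the scale.

The next compound is compound 4 `CC(=O)NN=C1C(Cl)=C(Cl)C(Cl)=C1Cl`. Its change from compound 3 is acetyl in place of tert-butyl on an amine nitrogen.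

Within the data shown here, no measured step covers this change, and the nearest analogues do not agree. Compound 1 carries carbonyl groups on that nitrogen and gives 800 nM. Compound 2 carries a carbonyl there too, yet yields only a limit, > 5000 nM.

The expected change, a step that the limit leaves unreadable from compound 3 to compound 4, is none beyond the usual scatter, with no direction favoured, and a further limit reading is quite possible. Compound 4 is estimated at 3500 nM, with an expected range of 1000 nM to 10000 nM.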

Compound 4, half-maximal inhibitory concentration: 1000 nM
Beside the measured number, compound 4's estimate is 3.5-fold (0.54 log units) above it; the range from low to high includes it.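

In this assay, among these compounds, acetyl in place of tert-butyl on an amine nitrogen gives an at least 3.0-fold lower number from compound 3 to compound 4 (0.47 log units; beyond the scatter), the first sign that the reading at this position depends on the group it carries. On the carbonyl carbon, methyl in place of (1,1-dimethylprop-2-yn-1-yl)oxy gives an at least 5.0-fold lower number from compound 2 to compound 4 (0.69 log units; beyond the scatter), so a carbonyl on that nitrogen does not by itself fix the reading. Each step is only a floor and not a true size, since its starting compound reads as a limit, as compound 3 does: the limit of > 3000 nM in this assay, at which 1 of the 4 values shown sits.

From the compounds shown here alone, how far compound 2 and compound 3 truly lie from compound 4 remains open. Also open, going by these compounds, is whether a propanoyl group, with a longer chain on the carbonyl carbon, or an amine on that carbon would keep the reading of compound 4.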